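Working notes: from compound 2 toward compound 4

This account rests on a few compounds, and the source may have more. Where it says the series, first, only, none or still open, it means among the compounds named here.

Measured compounds:
compound 1 `COc1cccc(/C=C2\CCC/C(=C\c3cccc(Cl)c3Cl)C2=O)c1OC` — > 20000 nM
compound 2 `COc1ccc(/C=C2\CCC/C(=C\c3ccccc3Cl)C2=O)cc1OC` — > 20000 nM
compound 3 `COc1ccc(/C=C2\CCC/C(=C\c3cc(OC)c(OC)c(OC)c3)C2=O)cc1OC` — 2900 nM
compound 4 `COc1ccc(/C=C2\CCC/C(=C\c3ccc(O)c(O)c3)C2=O)cc1OC` — not yet measured

In a functional assay on A549 cells (Homo sapiens) for cytotoxicity, read by MTT assay, with a stated time of 72 h (a higher number here means a weaker inhibitor, a lower number a stronger inhibitor), compound 2 gives > 20000 nM, which is a limit of the assay and not a number. Compound 2 stands at the limit of > 20000 nM in this assay, at which 2 of the 3 values shown sit. Compound 1 also gives only a limit in this assay, > 20000 nM. Within the data shown here, compound 3 is the single member of the series with a number in this assay, at 2900 nM, so no comparison of the measured compounds can be read as a step of known size.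

Compound 4 differs from compound 2 by 3,4-dihydroxyphenyl in place of 2-chlorophenyl on a double-bonded chain carbon bound to a double-bonded ring carbon. Among the measured compounds shown here, no measured pair shares this change, so its effect has to be guessed. The series gives one hint: compound 3, which carries a phenyl with oxygen substituents instead of a chlorinated phenyl, is the one that gives a measured number, 2900 nM. On that basis the step of an at least 2.5-fold lower number from compound 2 to compound 4 (0.39 log units; beyond the scatter) is expected to run toward a stronger inhibitor, beyond the usual scatter, though its true size cannot be fixed when the starting point is a limit. Compound 4 is estimated at 8000 nM in this assay, within a range from 2500 nM to 20000 nM, with a real chance that only a limit is reported again.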

Compound 4, half-maximal inhibitory concentration: > 20000 nM
Compound 4 ended at the assay's limit (the forecaster's own chance of this, stated with the estimate: 40%); at least 2.5-fold (0.39 log units) between middle value and limit.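

In this assay, among these compounds, compound 4 gives only a limit, as compound 2 does, so no step between the two compounds can be read. The compounds shown leave open whether 3,4-dihydroxyphenyl in place of 2-chlorophenyl changes the value at all, and by how much.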